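This account rests on a few compounds, and the source may have more. Where it says the series, first, only, none or still open, it means among the compounds named here.

Measured compounds in an assay on isolated protein for inhibition of histone deacetylase 8 (Homo sapiens), with a stated time of 1 h; a lower number here means a stronger inhibitor, a higher number a weaker inhibitor:
compound 1, `Cc1ccc(NC(=O)COc2ccc3cc(/C=C4/SC(=O)NC4=O)ccc3c2)cc1Cl`, gives > 50000 nM, which is a limit of the assay rather than a number.
compound 2, `O=C(COc1ccc2cc(/C=C3/SC(=O)NC3=O)ccc2c1)Nc1ccc(Br)cc1`, gives 16000 nM.
compound 3, `Cc1cccc(NC(=O)COc2ccc3cc(/C=C4/SC(=O)NC4=O)ccc3c2)n1`, gives 7500 nM.

Compound 1 stands at the weak end of this small set. Its result is only a limit (the limit of > 50000 nM in this assay, at which 1 of the 3 values shown sits), so the data say no more of it than that it is weaker than compound 2 and compound 3, whose steps from it are both beyond the scatter.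

Compound 4, `O=C(COc1ccc2cc(/C=C3/SC(=O)NC3=O)ccc2c1)Nc1c(F)cc(F)cc1Br`, is the compound still to be measured. It differs from compound 1 in one place: 2-bromo-4,6-difluorophenyl in place of 3-chloro-4-methylphenyl on an amide-type nitrogen.

Among the compounds with values here, two measured steps bear on this change, since both also replace the same group on the amide-type nitrogen: an at least 3.1-fold lower number from compound 1 to compound 2 (0.49 log units; beyond the scatter) and an at least 6.6-fold lower number from compound 1 to compound 3 (0.82 log units; beyond the scatter). Each replacement gave a lower number, at least modest in size. Compound 2, which carries a bromine-bearing ring like compound 4, gave the smaller of the two steps. On that basis compound 4 is expected to give a lower number than compound 1, a step of about an at least 2.5-fold lower number from compound 1 to compound 4 (0.39 log units; beyond the scatter) in this assay, though a limit again is possible. Compound 4 is estimated at 20000 nM, with a likely range from 6000 nM to 60000 nM.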

Compound 4, half-maximal inhibitory concentration: > 50000 nM
Compound 4 ended at the assay's limit; the forecaster's own chance of this, stated with the estimate: 30%; at least 2.5-fold (0.39 log units) between middle value and limit.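

Having a bromine on the ring was not enough for a gain in this assay: the 2-bromo-4,6-difluorophenyl group gives an at least 3.1-fold higher number from compound 2 to compound 4 (0.49 log units; beyond the scatter), and measured against the 6-methylpyridin-2-yl group it gives an at least 6.6-fold higher number from compound 3 to compound 4 (0.82 log units; beyond the scatter). The earlier compounds shown here showed only replacements of 3-chloro-4-methylphenyl that lowered the number, and compound 4 goes against that picture, so not every replacement on this amide-type nitrogen brings a gain. Compound 4 and compound 1 each end at a limit of the assay, so the step between them cannot be read and neither can be ranked against the other: the limit of > 50000 nM in this assay, at which 2 of the 4 values shown sit.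

The compounds shown leave open which part of the 2-bromo-4,6-difluorophenyl group matters, as the two fluorines and the bromine enter together and their separate contributions cannot be told apart. They also leave open how a plain phenyl group, or a ring carrying a carboxylic acid or an amine, would read on the same nitrogen in this assay.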